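The source may report more compounds than this note shows. Statements on the series, on what has been measured and on what is new or still open speak of the compounds shown alone.

In a toxicity assay (RAW264.7 cells) for cytotoxicity, with Mus musculus as the target, read by MTT assay, with a stated time of 4 h (a higher number here means a weaker inhibitor, a lower number a stronger inhibitor), compound 1 (`O=c1oc2c(O)cccc2cc1-c1cccc(O)c1`) is reported only as a limit, > 100000 nM. Compound 2 (`O=c1oc2cc(O)cc(O)c2cc1-c1cccc(O)c1`) is also reported only as a limit, > 100000 nM. For the measured compounds named here, compound 3 (`O=c1oc2c(O)c(O)ccc2cc1-c1ccccc1`) gives 26100 nM, the only actual number among the three values, so its standing against the other two cannot be sized.

Compound 4 (`O=c1oc2c(O)c(O)ccc2cc1-c1ccccc1O`) differs from compound 3 by a hydroxy in place of hydrogen on an aromatic carbon of a six-membered aromatic ring of carbon only, ortho to a large group: hydroxy in place of hydrogen on an aromatic carbon.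

Going by the values given here, the series holds no measured step for this change. Compound 1 and compound 2 each differ from compound 3 in more than one place, so neither offers a clean comparison. The expectation therefore rests on compound 3 at 26100 nM. The upper side of the expectation is set by the limit of > 100000 nM in this assay, at which 2 of the 3 values shown sit. A small change towards a weaker value in this assay is expected, possibly none beyond the scatter, and the estimated size is a 1.5-fold higher number from compound 3 to compound 4 (0.16 log units; within the scatter). A reported limit instead of a number also remains possible. For compound 4 the estimate is 38000 nM, with an expected range of 13000 nM to 100000 nM.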

Compound 4, half-maximal inhibitory concentration: 68900 nM
Compound 4: the middle estimate sits 1.8-fold (0.26 log units) below what was measured; the measured number falls inside the stated range.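

In this assay, hydroxy in place of hydrogen on an aromatic carbon of a six-membered aromatic ring of carbon only, ortho to a large group, gives a 2.6-fold higher number from compound 3 to compound 4 (0.42 log units; beyond the scatter). For the compounds shown here, this is the first single-change step available, and it shows that this position is not silent in this read-out: one added hydroxy moves the number modestly towards the weaker side, by more than the usual scatter. Room for further movement in that direction is narrow: the limit of > 100000 nM in this assay, at which 2 of the 4 values shown sit.

One step at one position sets no trend for the rest of the aromatic ring, and compound 1 and compound 2 are not linked to compound 3 or compound 4 by a single change, so the steps involving them cannot be read. Going by these compounds, whether a methoxy, an amine or a carboxylic acid at this same position would move the number in the same direction, or by a similar amount, remains open.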